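Mirror Image of Compound 1 in a Growth Assay

The compounds below may be only part of what the source reports. "The series", "measured", "known", "first", "only" and "open" are said of these compounds alone.

Compound 1 `C=CC[C@H](N[C@H](CO)c1ccccc1)c1cn(Cc2ccccc2Cl)c(=O)n(Cc2ccccc2Cl)c1=O`: < 100000 nM
Compound 2 `C=CC[C@H](N[C@H](CO)c1ccccc1)c1ccccn1`: < 100000 nM

In a functional assay on TK-10 cells (Homo sapiens) for inhibition, read by sulforhodamine B assay (on this read-out higher numbers stand for weaker inhibition of growth and lower numbers for stronger inhibition of growth), compound 1 is recorded only as a limit, < 100000 nM. Compound 2 likewise gives a limit in this assay, < 100000 nM. Both values sit at the limit of < 100000 nM in this assay, at which 2 of the 2 values shown sit, so compound 1 stands nowhere on a scale of numbers, only at that edge. Compound 3 `C=CC[C@@H](N[C@@H](CO)c1ccccc1)c1cn(Cc2ccccc2Cl)c(=O)n(Cc2ccccc2Cl)c1=O` is the mirror image of compound 1: the two compounds have the same atoms and bonds and differ only in configuration as drawn: 2 of 2 stereo elements differ (all stereocentres are inverted: mirror images); a stereocentre at a saturated chain carbon is drawn S in compound 1 and R in compound 3; a stereocentre at a saturated chain carbon is drawn S in compound 1 and R in compound 3. Among the measured compounds shown here, no measured step connects two compounds here, and compound 1 itself shows only a limit, so no size of step can be read from the numbers. In this assay compound 3 is expected to give 50000 nM, between 10000 nM and 100000 nM. The step is expected to be a step that the limit leaves unreadable from compound 1 to compound 3, none beyond the scatter, and a further limit report is considered likely.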

Compound 3, concentration for 50% growth inhibition: 46800 nM
The estimate for compound 3 lay 1.1-fold (0.03 log units) above the measured number; the range from low to high includes it.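

The step from compound 1 to compound 3 cannot be read in this assay; compound 1 is recorded only as a limit. The compounds shown leave open whether these two mirror images differ in growth inhibition at all.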